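Replacing the dithiocarbamate arm with an ethoxycarbonyl group

A few compounds are considered here, and "the series" means these few. Any claim that something is new, unique, unknown or untested is made for them only; others in the source may bear on it.

Compound 2 `CCNC(=S)SCC(=O)c1ccc(OC)cc1` gives the lowest of the three numbers measured in a functional assay on HeLa cells (Homo sapiens) for cytotoxicity, read by resazurin assay, with a stated time of 72 h (a higher number here means a weaker inhibitor, a lower number a stronger inhibitor), at 7800 nM. Its nearest neighbour is compound 1 `COc1ccc(C(=O)CSC(=S)SCCNC(C)=O)cc1`, which in this assay gives 11100 nM; the step of a 1.4-fold lower number from compound 1 to compound 2 (0.15 log units; within the scatter) keeps both within the usual scatter. Compound 3 `CCSC(=S)SCC(=O)c1ccc(NS(C)(=O)=O)cc1` stands furthest away, with 45800 nM in this assay, and that gap lies beyond the scatter.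

Compound 4 `CCOC(=O)SCC(=O)c1ccc(OC)cc1` has not been measured. It differs from compound 2 by a group of 5 heavy atoms (3 carbon, 2 oxygen; no ring) in place of a group of 5 heavy atoms (3 carbon, 1 nitrogen, 1 sulfur; no ring), on a sulfur, so that ethoxycarbonyl enters on a sulfur whose other neighbour is a saturated chain carbon. Among the compounds with values here, only one measured step bears on this site: a 1.4-fold lower number from compound 1 to compound 2 (0.15 log units; within the scatter), a change on the thiocarbonyl carbon that stayed within the scatter. Within the data shown here, no measured step exchanges the thiocarbonyl itself for a carbonyl, so the relevant history is thin. On that basis the expected step of a 1.5-fold higher number from compound 2 to compound 4 (0.19 log units; within the scatter) is small, with a slight lean toward a higher number. Compound 4 is therefore estimated at 12000 nM in this assay, with a range from 4000 nM to 40000 nM.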

Compound 4, half-maximal inhibitory concentration: 18500 nM
For compound 4 the middle estimate is 1.5-fold (0.19 log units) below the measured one; low and high end bracket the measured number.
By their numbers in this assay, from the lowest: compounds 2, 1 and 4 (each within the scatter of the next, the first and the last beyond it); then compound 3.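

In this assay, within the data shown here, the exchange on this sulfur gives a 2.4-fold higher number from compound 2 to compound 4 (0.38 log units; beyond the scatter), the first step at this site to pass beyond the scatter, whereas the earlier change on the thiocarbonyl carbon stayed within it. The ethoxycarbonyl group that enters carries 0 hydrogen-bond donors where the leaving group carries 1, and it also brings a carbonyl in place of the thiocarbonyl, so this one step alters the arm at two points at once. Nothing available offers an explanation for the step.

The compounds shown do not separate the share of the carbonyl from that of the oxygen replacing the amine nitrogen; an ethylaminocarbonyl group on the same sulfur would keep the nitrogen and change only the thiocarbonyl. As far as these compounds go, how a longer chain in place of the ethyl end would behave on the shared core also remains open.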